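The source may hold more compounds than are shown below. What is called first, only, known or untested is meant among the compounds shown, and "the series" means these compounds.

Measured compounds:
Compound 1, `CC(C)(C)C(=O)N1N=CCC1c1cocn1`: in an ADME assay on microsomes (Rattus norvegicus) for metabolic stability (on this read-out higher numbers stand for a longer-lived compound and lower numbers for a shorter-lived compound), compound 1 gives > 1.5 h, which is a limit of this assay and not a number.
Compound 2, `O=C(C1CCN(C(=O)C(F)(F)F)CC1)N1N=CCC1c1ccccc1`: in this assay compound 2 gives 0.483 h.
Compound 3, `O=C(c1cnco1)N1CCC(C(=O)N2N=CC[C@H]2c2ccccc2)CC1`: in this assay compound 3 gives > 3 h, again a limit rather than a number.

Among the three values shown, compound 2 therefore carries the only true number; the other two compounds are reported only as limits. Compound 1 sits at the limit of > 1.5 h in this assay, at which 1 of the 3 values shown sits. Compound 3 sits at the limit of > 3 h in this assay, at which 1 of the 3 values shown sits. Because the two limits give no number, no measured step in this assay can be worked out between any pair of these compounds, and nothing is known from them about how a change on the carbonyl carbon affects the read-out.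

Compound 4, `CCC(=O)N1CCC(C(=O)N2N=CCC2c2ccccc2)CC1`, is not yet measured. It differs from compound 2 in one place: ethyl in place of trifluoromethyl on a carbonyl carbon. Cut one bond further out, the (trifluoromethyl)carbonyl of compound 2 becomes a propanoyl in compound 4.

Going by the values given here, with no measured step of this kind to lean on, the step from compound 2 to compound 4 is expected to be small, within the usual scatter, with only a slight lean upward: a 1.2-fold higher number from compound 2 to compound 4 (0.09 log units; within the scatter). Compound 4 is therefore estimated to give about 0.6 h in this assay, in a range from 0.25 h to 1.5 h.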

Compound 4, half-life: 1.07 h
Compound 4: the middle estimate sits 1.8-fold (0.25 log units) below what was measured; the range from low to high includes it.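

Replacing trifluoromethyl with ethyl on a carbonyl carbon whose other neighbour is an amide-type nitrogen in a ring gives a 2.2-fold higher number from compound 2 to compound 4 (0.35 log units; beyond the scatter) in this assay. Going by these compounds alone, this is the first readable step, and it shows that the read-out at this position responds to the group on that carbonyl carbon, by a modest amount that lies beyond the scatter. No measured property shown here accounts for the step, and neither of the two limits in this assay bears on it.

The steps to compound 1 and compound 3 cannot be read, so this single pair stands alone and supports no trend across the series. From the compounds shown here alone, it remains open whether a longer chain such as butyl, a methyl group or an amine on the same carbonyl carbon would move the half-life further in the same direction, and whether the same exchange would give a similar step on a different core.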